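The source may report more compounds than this note shows. Statements on the series, on what has been measured and on what is new or still open speak of the compounds shown alone.

Working notes on the series. Compound 3 `O=C(/N=C(/NC(=O)c1cccs1)[Se]Cc1ccccc1)c1cccs1` and compound 1 `C[Se]/C(=N\C(=O)c1cccs1)NC(=O)c1cccs1` share one core; compound 2 `O=C(/N=C(/NC(=O)c1ccno1)[Se]Cc1ccccc1)c1ccno1` is built on another, and the difference between the two cores is not broken down here. In a functional assay on HT-29 cells (Homo sapiens) for cytotoxicity, read by MTT assay, with a stated time of 72 h (a lower number here means that less compound is tolerated, a higher number that more compound is tolerated), compound 3 gives > 100000 nM, a limit of the assay. Compound 1 gives > 100000 nM, also a limit. Compound 2 gives > 100000 nM, again a limit. The change hydrogen in place of phenyl on a saturated chain carbon bound to a selenium atom thus leaves a step that the two limits leave unreadable from compound 3 to compound 1, since (the limit of > 100000 nM in this assay, at which 3 of the 3 values shown sit). Compound 4 `C[Se]/C(=N\C(=O)c1ccno1)NC(=O)c1ccno1` carries the same change on the core of compound 2, (hydrogen in place of phenyl on a saturated chain carbon bound to a selenium atom). Because (the limit of > 100000 nM in this assay, at which 3 of the 3 values shown sit), the step expected is a step that the limit leaves unreadable from compound 2 to compound 4, read from the pair compound 3 to compound 1. Compound 3 sits at > 100000 nM, a limit. Compound 1 sits at > 100000 nM, also a limit. Compound 4 is therefore estimated at 150000 nM, most likely reported as a limit rather than a number.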

Compound 4, concentration lethal to 50% of the cells: > 100000 nM
Compound 4: no number, only a limit; the forecaster's own chance of this, stated with the estimate: 90%; the middle value lies beyond the limit too.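

No new step can be read from compound 2 to compound 4: both values are limits. The compounds shown leave open how benzyl and methyl compare on either core, and what number any of these compounds would give in this assay.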